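Same Atoms, Rejoined: A Reversed Amide Linker on the Aniline

This account rests on a few compounds, and the source may have more. Where it says the series, first, only, none or still open, it means among the compounds named here.

Of the compounds shown here, three sharing one core have been measured in a functional assay on A549 cells (Homo sapiens) for inhibition, read by CCK-8 assay, with a stated time of 72 h, tested at 10 uM; on this read-out higher numbers stand for a stronger effect at the one concentration tested and lower numbers for a weaker effect. Compound 1 `CN(C)C(=O)c1cc2cnc(Nc3ccc(S(=O)(=O)NCCCCCN=C=S)cc3)nc2n1C1CCCC1` gives 102%. Compound 2 `CN(C)C(=O)c1cc2cnc(Nc3ccc(C(=O)NCCCN=C=S)cc3)nc2n1C1CCCC1` gives 103%, and compound 3 `CN(C)C(=O)c1cc2cnc(Nc3ccc(C(=O)NCCCCCN=C=S)cc3)nc2n1C1CCCC1` gives 100%. Compound 3 sits alongside the other two: the step of a number 2 percentage points lower from compound 1 to compound 3 (within the scatter) and the step of a number 3 percentage points lower from compound 2 to compound 3 (within the scatter) both lie within the scatter, so no ordering among the three can be read from these numbers.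

Compound 4 `CN(C)C(=O)c1cc2cnc(Nc3ccc(NC(=O)CCCCCN=C=S)cc3)nc2n1C1CCCC1` has not yet been measured. Relative to compound 3 the change is a group of 11 heavy atoms (7 carbon, 2 nitrogen, 1 oxygen, 1 sulfur; no ring) in place of a group of 11 heavy atoms (7 carbon, 2 nitrogen, 1 oxygen, 1 sulfur; no ring), on an aromatic carbon; the two have the same atoms, joined differently, with the group sitting on the aromatic carbon para to the large group.

All three measured steps bear on this. Exchanging the linking group, a number 1 percentage points higher from compound 1 to compound 2 (within the scatter) and a number 2 percentage points lower from compound 1 to compound 3 (within the scatter), and lengthening the chain, a number 3 percentage points lower from compound 2 to compound 3 (within the scatter), each left the read-out within the scatter. No step beyond the scatter is therefore expected in this assay: the estimated step is no change at the digits printed from compound 3 to compound 4 (within the scatter). Compound 4 is expected to give about 100%, within 88% to 105%.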

Compound 4, a percentage reported as inhibition, at one concentration (the size of the read-out at that concentration, not a potency): 100%
For compound 4 middle estimate and measured number coincide at the digits printed, and the stated range covers the measured number.
By their numbers in this assay, from the lowest: compounds 3, 4, 1 and 2 (each within the scatter of the next).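

In this assay, reversing the amide on the aromatic carbon para to a large group, with the same atoms joined differently, gave no change at the digits printed from compound 3 to compound 4 (within the scatter), so this read-out does not tell the two joinings apart at this position. The reversed linker also stays within the scatter of the other two linkers, with a number 3 percentage points lower from compound 2 to compound 4 (within the scatter) and a number 2 percentage points lower from compound 1 to compound 4 (within the scatter), which adds amide direction to the exchange of linking group and the chain length as changes these numbers do not separate. No measurement at hand offers an explanation for this result.

Going by these compounds, all four compounds carry the terminal isothiocyanate, so the effect of an amine or a carboxylic acid in its place, or of a longer chain, remains open. On these data alone, whether the four would separate at a lower concentration also remains open.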